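Sec-Butyl in Place of 3,3-Dimethylbutyl: A Stability Question

The source may hold more compounds than are shown below. What is called first, only, known or untested is meant among the compounds shown, and "the series" means these compounds.

Measured in an in vitro ADME assay on microsomes from liver (Homo sapiens) for metabolic stability, tested at 5 uM; on this read-out lower numbers stand for a shorter-lived compound and higher numbers for a longer-lived compound:
Compound 1 `CC(C)CCn1nc(-c2cccs2)c(O)c(C2=NS(=O)(=O)c3cc(S(=O)(=O)N(C)C)ccc3N2)c1=O`: 0.183 h
Compound 2 `CC(C)(C)CCn1nc(-c2cccs2)c(O)c(C2=NS(=O)(=O)c3cc(NS(C)(=O)=O)ccc3N2)c1=O`: > 1 h

Of the compounds shown here, two sharing one core have been measured so far, and only compound 1 has an exact number. Compound 2 stands at > 1 h, which is a limit of the assay and not a number. Its true half-life in this assay is therefore unknown.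

The next compound is compound 3 `CCC(C)n1nc(-c2cccs2)c(O)c(C2=NS(=O)(=O)c3cc(NS(C)(=O)=O)ccc3N2)c1=O`. It carries sec-butyl in place of 3,3-dimethylbutyl on an aromatic nitrogen. The rest of the structure is that of compound 2.

Within the data shown here, no measured pair differs in a single place, so the data offer no step by which to size this change. The expectation starts from the limit of compound 2 and allows for a modest move towards a shorter-lived compound, not far beyond the usual scatter. The expected step is an at least 1.2-fold lower number from compound 2 to compound 3 (0.09 log units; that floor lies within the scatter). For compound 3 the estimated half-life is 0.8 h, with an expected range of 0.3 h to 2 h.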

Compound 3, half-life: > 1 h
Compound 3: a limit, no number; the forecaster's own chance of this, stated with the estimate: 40%; middle value at least 1.2-fold (0.09 log units) from the limit.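

In this assay compound 3 gives > 1 h, a limit of the assay and not a number. No step from compound 2 to compound 3 can be read, because both stand at the same limit: the limit of > 1 h in this assay, at which 2 of the 3 values shown sit.

The compounds shown leave open whether sec-butyl and 3,3-dimethylbutyl differ at all in this assay.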